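The compounds below may be only part of what the source reports. "The series", "measured", "known", "first", "only" and "open" are said of these compounds alone.

Measured so far in a functional assay on HCT-116 cells (Homo sapiens) for antiproliferative activity, read by luminescence, with a stated time of 72 h (on this read-out lower numbers stand for stronger inhibition and higher numbers for weaker inhibition), with the values as shown
- compound 1 `CCOC(=O)N1CC2(CC(=O)c3cc(/C=C/C(=O)NO)ccc3O2)C1` gives 1230 nM
- compound 2 `O=C(/C=C/c1ccc2c(c1)C(=O)CC1(CN(Cc3ccccc3)C1)O2)NO` gives 76 nM

Compound 2 holds the lower of the two numbers at 76 nM in this assay and is the reference for the next comparison. Compound 3 `O=C(/C=C/c1ccc2c(c1)C(=O)CC1(CN(Cc3ccc(F)cc3)C1)O2)NO` differs from it by one substitution fluoro in place of hydrogen on an aromatic carbon with fluoro in place of hydrogen on an aromatic carbon, para to a large group, so that benzyl becomes 4-fluorobenzyl.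

Among the compounds with values here, only one measured step bears on this change. It is a 16-fold lower number from compound 1 to compound 2 (1.21 log units; beyond the scatter) and it is large, with benzyl in place of ethoxycarbonyl on the amine nitrogen in a ring. That step shows that the number can move with the group on this nitrogen, but it replaces a whole group. Within the data shown here, no measured pair isolates fluoro in place of hydrogen, so its size cannot be carried over. Going by these compounds, no step beyond the scatter is expected, and the direction stays open. The expected change is a 1.1-fold lower number from compound 2 to compound 3 (0.04 log units; within the scatter) as an estimate. Compound 3 is estimated at 70 nM with an expected range from 30 nM to 160 nM in this assay when measured.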

Compound 3, half-maximal inhibitory concentration: 190 nM
The estimate for compound 3 lay 2.7-fold (0.43 log units) below the measured number; measured number above the stated range.
By their numbers in this assay, from the lowest: compound 2; then compound 3; then compound 1.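

In this assay the aromatic ring of the benzyl group responds to a single substitution: fluoro in place of hydrogen, para to a large group, gives a 2.5-fold higher number from compound 2 to compound 3 (0.40 log units; beyond the scatter) and so moves the number beyond the scatter in the direction of weaker inhibition. Until now, only the exchange of a whole group on the amine nitrogen had been seen to move the number, and this step shows that a change further out from that nitrogen can do so as well. The 4-fluorobenzyl group still keeps part of the advantage over ethoxycarbonyl, with a 6.5-fold lower number from compound 1 to compound 3 (0.81 log units; beyond the scatter) against the larger 16-fold lower number from compound 1 to compound 2 (1.21 log units; beyond the scatter) for benzyl, so at this nitrogen the unsubstituted benzyl group of compound 2 remains the best of the three groups shown. No measurement shown accounts for the loss on adding fluoro.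

Going by these compounds, with fluoro as the only ring substituent here, it remains open whether chloro, methyl or methoxy at the same place would give a similar step, or whether any substituent there raises the number. Also open, on these data alone, is how the number responds to fluoro elsewhere on the ring, or to a longer chain such as phenethyl on the amine nitrogen.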